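From Hydroxy to Fluoro on a Growth Inhibitor

The source may hold more compounds than are shown below. What is called first, only, known or untested is meant among the compounds shown, and "the series" means these compounds.

Measured values from a functional assay on PC-3 cells (Homo sapiens) for inhibition; a higher number here means a weaker inhibitor of growth, a lower number a stronger inhibitor of growth
- compound 1 `COc1ccc(-n2cnnc2-c2cc(OC)c(OC)c(OC)c2)cc1` gives 4900 nM
- compound 2 `COc1cc(-c2nncn2-c2ccc(N(C)C)cc2)cc(OC)c1OC` gives 28.2 nM
- compound 3 `COc1ccc(-n2cnnc2-c2cc(OC)c(OC)c(OC)c2)cc1O` gives 288 nM

Compound 3, at 288 nM, stands second highest of the three numbers, well below compound 1 and well above compound 2. The next compound, compound 4 `COc1ccc(-n2cnnc2-c2cc(OC)c(OC)c(OC)c2)cc1F`, has fluoro in place of hydroxy on an aromatic carbon, ortho to a methoxy group and meta to a large group, and fluoro in place of hydroxy on an aromatic carbon sums up that change.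

The most relevant evidence is a 17-fold lower number from compound 1 to compound 3 (1.23 log units; beyond the scatter), a large step made by hydroxy in place of hydrogen on this same carbon. The other measured change, a 170-fold lower number from compound 1 to compound 2 (2.24 log units; beyond the scatter), is also large, but it is made elsewhere, with dimethylamino in place of methoxy, so it bears on this question only weakly. Going by the values given here, compound 4 no longer has the hydroxy, and no measured compound carries fluoro, so the uncertainty is wide. A moderate move towards weaker growth inhibition is expected, and the estimated change is a 2.8-fold higher number from compound 3 to compound 4 (0.44 log units; beyond the scatter) in this assay as a modest rise. For compound 4 the estimate is 800 nM, with an expected range from 170 nM to 3500 nM as the likely limits.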

Compound 4, concentration for 50% growth inhibition: 3020 nM
Compound 4: middle estimate off by 3.8-fold (0.58 log units), on the low side; the measured number falls inside the stated range.
By their numbers in this assay, from the lowest: compound 2; then compound 3; then compounds 4 and 1 (each within the scatter of the next).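

In this assay, putting fluoro where the hydroxy stood gives a 10-fold higher number from compound 3 to compound 4 (1.02 log units; beyond the scatter) and so removes the gain that hydroxy brought to this carbon. Set against the compound with only hydrogen here, the fluoro compound shows a 1.6-fold lower number from compound 1 to compound 4 (0.21 log units; within the scatter) and stays within the scatter, so the two cannot be told apart in this assay. The gain therefore belongs to hydroxy and does not appear with this other small group on the same carbon, though no available evidence explains the difference.

Going by these compounds, whether an amino group or a carboxylic acid on this carbon would match hydroxy remains open. Also open, on these data alone, is whether hydroxy on this carbon would add to the dimethylamino group of compound 2 if the two stood on one compound.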